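Swapping the aryl amide substituent: methoxy to methyl

A few compounds are considered here, and "the series" means these few. Any claim that something is new, unique, unknown or untested is made for them only; others in the source may bear on it.

Compound 3 `COc1cc(OC)cc(C(=O)Nc2cccc(-c3oc4cc(-c5ccc(F)cc5)ccc4c(=O)c3O)c2)c1` is one of three amides built on a shared core. In a functional assay on HCC1937 cells (Homo sapiens) for antiproliferative activity, read by CCK-8 assay, with a stated time of 72 h (on this read-out higher numbers stand for weaker inhibition and lower numbers for stronger inhibition), compound 3 gives 6250 nM. Compound 1 `O=C(Nc1cccc(-c2oc3cc(-c4ccc(F)cc4)ccc3c(=O)c2O)c1)c1ccc(F)cc1F` gives 6980 nM in this assay, and compound 2 `O=C(Nc1cccc(-c2oc3cc(-c4ccc(F)cc4)ccc3c(=O)c2O)c1)c1cccc(F)c1` gives 6590 nM. The three numbers sit within the scatter of one another, so compound 3 stands level with the others. Compound 4 `Cc1cc(C)cc(C(=O)Nc2cccc(-c3oc4cc(-c5ccc(F)cc5)ccc4c(=O)c3O)c2)c1` carries 3,5-dimethylphenyl in place of 3,5-dimethoxyphenyl on a carbonyl carbon. Among the compounds with values here, two measured steps touch the same aryl group on the carbonyl carbon: a 1.1-fold lower number from compound 1 to compound 3 (0.05 log units; within the scatter) and a 1.1-fold lower number from compound 2 to compound 3 (0.02 log units; within the scatter), neither beyond the scatter. On that basis a step of a 1.0-fold higher number from compound 3 to compound 4 (0.02 log units; within the scatter) is expected for compound 4. The estimate for compound 4 is therefore 6500 nM, with a range from 3000 nM to 14000 nM.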

Compound 4, half-maximal inhibitory concentration: 4860 nM
Compound 4: the middle estimate sits 1.3-fold (0.13 log units) above what was measured; the range from low to high includes it.
By their numbers in this assay, from the lowest: compounds 4, 3, 2 and 1 (each within the scatter of the next).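

In this assay, the change to 3,5-dimethylphenyl on the carbonyl carbon gives a step within the scatter (a 1.3-fold lower number from compound 3 to compound 4 (0.11 log units; within the scatter)), and the other two steps also stay within it (a 1.4-fold lower number from compound 2 to compound 4 (0.13 log units; within the scatter); a 1.4-fold lower number from compound 1 to compound 4 (0.16 log units; within the scatter)). This position therefore now holds an aryl group with no hydrogen-bond acceptors, and none of the four compounds stands apart from the others. Nothing measured here accounts for this. As far as these compounds go, whether an amine, a carboxylic acid or a longer chain at this carbonyl carbon would give a step beyond the scatter remains open.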